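Moving the amide substituent back toward a two-position group

The source may report more compounds than this note shows. Statements on the series, on what has been measured and on what is new or still open speak of the compounds shown alone.

Measured compounds:
compound 1, `N#Cc1ccc(Cn2cncc2CN(C(=O)c2ccccc2F)c2ccc(N3CCN(C(=O)c4ccc(Cl)s4)CC3)cc2)cc1`: 20 nM
compound 2, `N#Cc1ccc(Cn2cncc2CN(C(=O)c2cccc(F)c2)c2ccc(N3CCN(C(=O)c4ccc(Cl)s4)CC3)cc2)cc1`: 6 nM

Compound 2 has the lowest of the two numbers in a functional assay on DLD-1 cells (Homo sapiens); a lower number here means a stronger inhibitor, a higher number a weaker inhibitor; its nearest neighbour is compound 1, with a number that is higher by a 3.3-fold lower number from compound 1 to compound 2 (0.52 log units; beyond the scatter) beyond the scatter. The unmeasured compound 3, `COc1ccccc1C(=O)N(Cc1cncn1Cc1ccc(C#N)cc1)c1ccc(N2CCN(C(=O)c3ccc(Cl)s3)CC2)cc1`, differs from compound 2 by 2-methoxyphenyl in place of 3-fluorophenyl on a carbonyl carbon. Among the measured compounds shown here, only one measured step speaks to this change: going from compound 1 to compound 2, a 3.3-fold lower number from compound 1 to compound 2 (0.52 log units; beyond the scatter), shows that the 2-fluorophenyl gives the higher number and the 3-fluorophenyl the lower. For the measured compounds named here, compound 3 returns to a group carried on the 2-position of the phenyl, and no measured compound holds a methoxy, so the expected step is taken from that single comparison: a modest rise in the number, estimated at a 3.3-fold higher number from compound 2 to compound 3 (0.52 log units; beyond the scatter). For compound 3 the estimated value in this assay is 20 nM, with a range from 6 nM to 70 nM.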

Compound 3, half-maximal inhibitory concentration: > 10000 nM
Compound 3 ended at the assay's limit (the forecaster's own chance of this, stated with the estimate: 2%); at least 500-fold (2.69 log units) between middle value and limit.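

In this assay, the change to 2-methoxyphenyl gives an at least 1600-fold higher number from compound 2 to compound 3 (3.22 log units; beyond the scatter), and methoxy in place of fluoro on an aromatic carbon gives an at least 500-fold higher number from compound 1 to compound 3 (2.69 log units; beyond the scatter). Compound 1, with its 2-fluorophenyl, stays at 20 nM, so the loss does not follow from substitution at that ring position alone; it appears only with the methoxy, a far larger step than the modest one between the two fluorophenyl compounds. Compound 3 stands at a limit of the assay, not at a number: the limit of > 10000 nM in this assay, at which 1 of the 3 values shown sits.

Going by these compounds, the true value of compound 3 stays unknown, and its steps are only bounds. On these data alone, it also remains open whether the loss follows the methoxy to other places on the ring, and how a methyl, a chloro or an amine would fare in its place.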